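Swapping the tert-butylphenyl for a dimethoxyphenyl amide

A few compounds are considered here, and "the series" means these few. Any claim that something is new, unique, unknown or untested is made for them only; others in the source may bear on it.

Of the compounds shown here, two of the shared core have been tested in a functional assay on MGC-803 cells (Homo sapiens) for inhibition, read by MTT assay, with a stated time of 48 h; on this read-out lower numbers stand for stronger inhibition and higher numbers for weaker inhibition. Compound 1 `COc1cc(N(Cc2nc3ccccc3[nH]2)C(=O)c2ccc(F)cc2)cc(OC)c1OC` gives 23600 nM. For compound 2 `COc1cc(N(Cc2nc3ccccc3[nH]2)C(=O)c2ccc(C(C)(C)C)cc2)cc(OC)c1OC` the assay reports only a limit, > 50000 nM, not a number. Among the measured compounds shown here, the one measured step, an at least 2.1-fold higher number from compound 1 to compound 2 (0.32 log units; beyond the scatter), is therefore known only as a lower bound, because of the limit of > 50000 nM in this assay, at which 1 of the 2 values shown sits.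

Compound 3 `COc1ccc(C(=O)N(Cc2nc3ccccc3[nH]2)c2cc(OC)c(OC)c(OC)c2)cc1OC` differs from compound 2 by 3,4-dimethoxyphenyl in place of 4-(tert-butyl)phenyl on a carbonyl carbon. For the measured compounds named here, the only step seen so far exchanged one small substituent for a bulkier one on the same ring and weakened inhibition at least modestly; nothing measured shows the effect of two methoxy groups on that ring. The expectation is a step of an at least 1.6-fold lower number from compound 2 to compound 3 (0.22 log units; that floor lies within the scatter), meaning compound 3 is expected to land near where compound 1 sits, with a real chance that this assay again returns only a limit. Compound 3 is estimated at 30000 nM, with a range from 10000 nM to 90000 nM.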

Compound 3, half-maximal inhibitory concentration: 22400 nM
Compound 3: middle estimate off by 1.3-fold (0.13 log units), on the high side, within the range that was stated.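

On a carbonyl carbon, 3,4-dimethoxyphenyl in place of 4-(tert-butyl)phenyl gives an at least 2.2-fold lower number from compound 2 to compound 3 (0.34 log units; beyond the scatter) in this assay, so the weak result of compound 2 does not extend to every group of equal heavy-atom count at this position. Against 4-fluorophenyl, the same group gives a 1.1-fold lower number from compound 1 to compound 3 (0.02 log units; within the scatter), so compound 1 and compound 3 cannot be told apart here, although the two groups differ in what they carry on the ring. The step from compound 2 is only a lower bound, because compound 2 stands at a limit and not at a number: the limit of > 50000 nM in this assay, at which 1 of the 3 values shown sits.

Open, from the compounds shown here alone, is how far compound 2 truly lies from the other two. Also open, going by these compounds, is whether an amine, a carboxylic acid or a single methoxy group on this ring would move the number beyond the scatter from compound 1 and compound 3.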